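The source may report more compounds than this note shows. Statements on the series, on what has been measured and on what is new or still open speak of the compounds shown alone.

Measured compounds in the series:

- compound 1 `C=CC(=O)Nc1cccc(NC(=O)CSc2nc(Nc3ccccc3Br)c3ccccc3n2)c1`: 19300 nM
- compound 2 `C=CC(=O)Nc1cccc(NC(=O)CSc2nc(Nc3cccc(Br)c3)c3ccccc3n2)c1`: 12100 nM
- compound 3 `C=CC(=O)Nc1cccc(NC(=O)CSc2nc(Nc3cccc(OC)c3)c3ccccc3n2)c1`: 7940 nM

All three numbers come from a functional assay on NCI-H1975 cells (Homo sapiens) for inhibition, read by MTT assay, with a stated time of 72 h; a higher number here means a weaker inhibitor, a lower number a stronger inhibitor. Compound 3 has the lowest number of the three, but its step to compound 2 is within the scatter, and only its step to compound 1 is beyond it, so compound 3 is the lowest on the numbers shown without being clearly set apart from compound 2.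

The next compound is compound 4 `C=CC(=O)Nc1cccc(NC(=O)CSc2nc(Nc3ccc(Cl)cc3)c3ccccc3n2)c1`. The change from compound 3 is 4-chlorophenyl in place of 3-methoxyphenyl on a nitrogen on an aromatic ring.

Among the measured compounds shown here, three measured steps bear on this, all being changes of the aryl group on the same nitrogen: a 1.6-fold lower number from compound 1 to compound 2 (0.20 log units; within the scatter), a 2.4-fold lower number from compound 1 to compound 3 (0.39 log units; beyond the scatter) and a 1.5-fold lower number from compound 2 to compound 3 (0.18 log units; within the scatter). All are small; the largest is only modest. For the measured compounds named here, no measured step gives a 4-chlorophenyl on this nitrogen, so its effect is not known directly. In this assay the expected step is a 1.3-fold higher number from compound 3 to compound 4 (0.10 log units; within the scatter), a number near compound 3 or somewhat higher, with no change beyond the scatter expected with confidence.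

For compound 4 the estimate in this assay is 10000 nM, with a range from 4000 nM to 25000 nM.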

Compound 4, half-maximal inhibitory concentration: 7580 nM
Estimate against measurement, compound 4: 1.3-fold (0.12 log units) above, and the stated range covers the measured number.
By their numbers in this assay, from the lowest: compounds 4, 3, 2 and 1 (each within the scatter of the next, the first and the last beyond it).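

In this assay, 4-chlorophenyl on this nitrogen gives a 1.0-fold lower number from compound 3 to compound 4 (0.02 log units; within the scatter) and a 1.6-fold lower number from compound 2 to compound 4 (0.20 log units; within the scatter), so it cannot be told apart from 3-methoxyphenyl or 3-bromophenyl, and going from 1 hydrogen-bond acceptor in the leaving group to 0 in the entering group leaves the number within the scatter. The comparison with 2-bromophenyl gives a 2.5-fold lower number from compound 1 to compound 4 (0.41 log units; beyond the scatter), the same modest size as the step to compound 3, so compound 1 stands apart from compounds 3 and 4 but not from compound 2. No measurement here explains these numbers.

Each aryl swap shown changes the substituent and its place on the ring together, so the two remain unseparated. Also open, going by these compounds, is how this nitrogen responds to an aryl group carrying an amine or a carboxylic acid, or to a cyclohexyl group.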